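The source may report more compounds than this note shows. Statements on the series, on what has been measured and on what is new or still open speak of the compounds shown alone.

In an assay on isolated protein for inhibition of Indoleamine 2,3-dioxygenase 1 (Homo sapiens), read by spectrophotometry (a higher number here means a weaker inhibitor, a lower number a stronger inhibitor), compound 1 `O/N=C(/Nc1cccc(Cl)c1)c1ccc2occc2c1` gives 690 nM. Compound 2 `COCc1cc2cc(/C(=N\O)Nc3cccc(F)c3)ccc2o1` adds a methoxymethyl group to the shared core and carries a fluoro group in place of the chloro group of compound 1. In this assay compound 2 gives 7100 nM. That is the higher of the two numbers and so the weaker inhibitor, and the gap to compound 1 is beyond the usual scatter.

Compound 3 `COCc1cc2cc(/C(=N\O)Nc3cccc(Cl)c3)ccc2o1` keeps everything in compound 2 except one change: chloro in place of fluoro on an aromatic carbon. Among the compounds with values here, no measured pair differs only in this way, so the size of the step is uncertain. Compound 1 also carries a chloro group and stands far lower than compound 2, but it lacks the methoxymethyl group, so its value cannot be split between the two differences. A modest gain is expected, a 2.4-fold lower number from compound 2 to compound 3 (0.37 log units; beyond the scatter). Compound 3 is expected to give about 3000 nM in this assay, likely between 1000 nM and 9000 nM.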

Compound 3, half-maximal inhibitory concentration: 1000 nM
Compound 3: the middle estimate sits 3.0-fold (0.48 log units) above what was measured; the measured number falls inside the stated range.
By their numbers in this assay, from the lowest: compounds 1 and 3 (each within the scatter of the next); then compound 2.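

In this assay the swap from 3-fluorophenyl to 3-chlorophenyl, with everything else held fixed, gives a 7.1-fold lower number from compound 2 to compound 3 (0.85 log units; beyond the scatter) and so shows that this place on the aromatic ring is sensitive to which of these two atoms it carries. Compound 3 also isolates the second difference: methoxymethyl in place of hydrogen gives a 1.4-fold higher number from compound 1 to compound 3 (0.16 log units; within the scatter) and so, with chloro present, this added group has no effect that can be told from the scatter. Nothing measured here accounts for the size of the chloro and fluoro step.

Whether methoxymethyl is equally without effect when fluoro is present remains open, since the matching compound without methoxymethyl is not among those shown. Also open, on these data alone, is how a bromo or methoxy group would behave at the chloro position, and how an amine or a longer chain would compare with methoxymethyl.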